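A few compounds are considered here, and "the series" means these few. Any claim that something is new, unique, unknown or untested is made for them only; others in the source may bear on it.

Measured so far in an ADME assay on L1210/0 cells (Mus musculus) for cytotoxicity, with a stated time of 48 h; a lower number here means a stronger inhibitor, a higher number a weaker inhibitor: compound 1 `O=C1O/C(=C\Cn2cc(I)c(=O)[nH]c2=O)C(OCc2ccccc2)=C1OCc1ccccc1` gives 7500 nM; compound 2 `O=C1O/C(=C\Cn2ccc(=O)[nH]c2=O)C(OCc2ccccc2)=C1OCc1ccccc1` gives 12900 nM. Compound 3 `CC1(C)[C@@H](CO)CC[C@@]1(C)Cn1cc(I)c(=O)[nH]c1=O` reaches only a limit of this assay, > 200000 nM.

Compound 4 `CC1(C)[C@@H](CO)CC[C@@]1(C)Cn1ccc(=O)[nH]c1=O` has not yet been measured. The change from compound 3 to compound 4 is hydrogen in place of iodo on an aromatic carbon. The same change, (hydrogen in place of iodo on an aromatic carbon), links compound 1 to compound 2, where it made a 1.7-fold higher number from compound 1 to compound 2 (0.24 log units; within the scatter). The difference between the core of compound 1 and the core of compound 3 is not broken down here. For compound 4 the expected step is a step that the limit leaves unreadable from compound 3 to compound 4. This expectation rests on compound 1 and compound 2, whose step is a 1.7-fold higher number from compound 1 to compound 2 (0.24 log units; within the scatter), and on compound 3 sitting at the limit of > 200000 nM in this assay, at which 1 of the 3 values shown sits. Compound 4 is therefore estimated at 300000 nM, expected to lie between 100000 nM and 1000000 nM, most likely reported again only as a limit.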

Compound 4, half-maximal inhibitory concentration: > 200000 nM
Compound 4: only a limit was reported (the forecaster's own chance of this, stated with the estimate: 85%); the middle value is on the limit's open side.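

Among these compounds, compound 3 and compound 4 both give only a limit, not a number, so no step between them can be read: the limit of > 200000 nM in this assay, at which 2 of the 4 values shown sit. From the compounds shown here alone, whether hydrogen in place of iodo changes anything on this core stays open.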